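Thiazolylmethoxy in Place of the Hydroxy Sulfone Ring

The source may hold more compounds than are shown below. What is called first, only, known or untested is meant among the compounds shown, and "the series" means these compounds.

Measured compounds:
Compound 1 `Cc1c(C)c(-c2cccc(COc3ccc4c(c3)OC[C@H]4CC(=O)O)c2)c(C)c(C)c1OC1CCS(=O)(=O)CC1` gives 29 nM in a functional assay on CHO cells for agonist activity at Free fatty acid receptor 1 (Homo sapiens), read by FLIPR and calcium flux, with a stated time of 90 s, in the presence of a further agent that is not named here; on this read-out lower numbers stand for an effect already at smaller amounts and higher numbers for an effect only at larger amounts of compound.
Compound 2 `Cc1cc(OCC2(O)CCS(=O)(=O)CC2)cc(C)c1-c1cccc(COc2ccc3c(c2)OC[C@H]3CC(=O)O)c1` gives 13 nM in this assay.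

Compound 2 holds the lower of the two numbers seen so far in this assay. Within the data shown here, compound 1 is its only neighbour, and compound 1 sits at a higher number, a gap that lies beyond the usual scatter of this read-out. Among the measured compounds shown here, both share the same core, and the two differ in more than one place, so no single step between them is set out here; only their two values can be compared.

Compound 3 `Cc1nc(C)c(COc2cc(C)c(-c3cccc(COc4ccc5c(c4)OC[C@H]5CC(=O)O)c3)c(C)c2)s1` has not been measured in this assay. Its difference from compound 2 is 2,4-dimethyl-1,3-thiazol-5-yl in place of 4-hydroxy-1,1-dioxothian-4-yl on a saturated chain carbon bound to an oxygen on an aromatic ring. The part that leaves is a ring that is saturated and carries a hydroxyl and a sulfone; the part that enters is aromatic and lacks a donor.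

From compound 2 to compound 3 the step in this assay is expected to be small, either none beyond the scatter or a modest move toward a higher number, as a 1.7-fold higher number from compound 2 to compound 3 (0.23 log units; within the scatter). For compound 3 the estimated value in this assay is 22 nM, within a range of 7 nM to 70 nM.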

Compound 3, half-maximal effective concentration in the Free fatty acid receptor 1 assay: 18 nM
Compound 3: the middle estimate sits 1.2-fold (0.09 log units) above what was measured; the range from low to high includes it.
By their numbers in the Free fatty acid receptor 1 assay, from the lowest: compounds 2, 3 and 1 (each within the scatter of the next, the first and the last beyond it).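

In the Free fatty acid receptor 1 assay, 2,4-dimethyl-1,3-thiazol-5-yl in place of 4-hydroxy-1,1-dioxothian-4-yl gives a 1.4-fold higher number from compound 2 to compound 3 (0.14 log units; within the scatter). On this saturated chain carbon, then, an aromatic five-membered ring with no hydrogen-bond donor stands in for a saturated ring carrying a hydroxyl and a sulfone, with no step beyond the scatter. In a physicochemical assay for lipophilicity, read by HPLC, at pH 7.4 (on this read-out lower numbers stand for lower lipophilicity and higher numbers for higher lipophilicity), compound 2 gives 2.43 and compound 3 gives 4.27, so a change that leaves the number in the Free fatty acid receptor 1 assay within the scatter still brings a large rise in lipophilicity: the measured distribution coefficient of compound 2, 2.43, and of compound 3, 4.27, a number 1.84 log units higher (beyond the scatter)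

The compounds shown do not tell whether the two methyl groups on the thiazole matter for either read-out, or how an unsubstituted 1,3-thiazol-5-yl would compare on the same chain carbon. They also leave open whether a ring with a basic nitrogen, such as a morpholine or a pyridine, would hold the number in the Free fatty acid receptor 1 assay at this position, and where its value in the physicochemical assay would fall relative to those of the sulfone and the thiazole.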